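This account rests on a few compounds, and the source may have more. Where it says the series, first, only, none or still open, it means among the compounds named here.

Three compounds have been measured in a functional assay on MGC-803 cells (Homo sapiens) for cytotoxicity, read by MTT assay, with a stated time of 72 h; a lower number here means a stronger inhibitor, a higher number a weaker inhibitor:

Compound 1 `O=C(CSC(=S)N[C@H]1CCOC1=O)Nc1ccc(Br)cc1` gives 42800 nM
Compound 2 `O=C(CSC(=S)N[C@H]1CCOC1=O)Nc1ccc(F)cc1` gives 37600 nM
Compound 3 `O=C(CCl)Nc1ccc(C(=O)/C=C/c2ccc(Br)cc2)cc1` gives 6050 nM

Compound 1 and compound 2 share one core and differ in a single spot, (fluoro in place of bromo on an aromatic carbon). That change produced a 1.1-fold lower number from compound 1 to compound 2 (0.06 log units; within the scatter). Compound 3 rests on a different core; the difference between the two cores is not broken down here. In this assay compound 3 stands lowest of the three, with compound 2 nearest and compound 1 furthest.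

Compound 4 `O=C(CCl)Nc1ccc(C(=O)/C=C/c2ccc(F)cc2)cc1` has not yet been measured. It stands to compound 3 exactly as compound 2 stands to compound 1: the same change, at the same kind of place, (fluoro in place of bromo on an aromatic carbon). Because the step of a 1.1-fold lower number from compound 1 to compound 2 (0.06 log units; within the scatter) lay within the scatter, a similarly small step is expected, a 1.1-fold lower number from compound 3 to compound 4 (0.04 log units; within the scatter). Compound 4 is therefore estimated at 5500 nM, with a likely range from 2500 nM to 12000 nM.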

Compound 4, half-maximal inhibitory concentration: 4680 nM
Beside the measured number, compound 4's estimate is 1.2-fold (0.07 log units) above it, within the range that was stated.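

Replacing 4-bromophenyl with 4-fluorophenyl gave a 1.3-fold lower number from compound 3 to compound 4 (0.11 log units; within the scatter) in this assay, so the swap leaves no readable difference on this core. Set beside the earlier case, the two cores agree: the same change on two cores in this assay, a 1.1-fold lower number (0.06 log units; within the scatter) from compound 1 to compound 2 and a 1.3-fold lower number (0.11 log units; within the scatter) from compound 3 to compound 4, 1.1-fold (0.06 log units) apart, within the scatter of two such steps. This shows that the change had no readable effect on either of these two cores in this one assay, but it does not show that the same would hold on a third core, or what either group does inside the cells.

The compounds shown carry only bromo or fluoro at this place on the ring. From the compounds shown here alone, it remains open whether an amine, a carboxylic acid or a methoxy group there would shift the number beyond the scatter.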